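Phenylsulfonyl in Place of 3-Chlorobenzyl: Expectation for Compound 4

The compounds below may be only part of what the source reports. "The series", "measured", "known", "first", "only" and "open" are said of these compounds alone.

Three compounds have numbers in an assay on BTI cells for inhibition of Amine oxidase [flavin-containing] B (Homo sapiens), read by fluorescence, with stated times of 30 min and 1 h, tested at 1 uM; a higher number here means more inhibition at the concentration tested (going by the name of the read-out), a lower number less inhibition. Compound 1 `C[C@H](NCc1ccc(OCCCN2CCN(c3cccc4c3ccn4Cc3cccc(Cl)c3)CC2)cc1)C(N)=O` gives 47%, compound 2 `C[C@H](NCc1ccc(OCCCCCN2CCN(c3cccc4c3ccn4Cc3cccc(Cl)c3)CC2)cc1)C(N)=O` gives 43%, and compound 3 `C[C@H](NCc1ccc(OCCCCN2CCN(c3cccc4c3ccn4S(=O)(=O)c3ccccc3)CC2)cc1)C(N)=O` gives 20%. Compound 2 stands second of the three; its number and that of compound 1 lie within the scatter of each other, while compound 3 sits below both, beyond the scatter. Compound 4 `C[C@H](NCc1ccc(OCCCCCN2CCN(c3cccc4c3ccn4S(=O)(=O)c3ccccc3)CC2)cc1)C(N)=O` is not yet measured. It differs from compound 2 in one place: phenylsulfonyl in place of 3-chlorobenzyl on an aromatic nitrogen. For the measured compounds named here, no pair of measured compounds carries this change alone, so no step for it is known. Still, compound 3 carries phenylsulfonyl on the same aromatic nitrogen and gives 20%, far under compound 2. A downward step beyond the scatter is expected in this assay: a number 21 percentage points lower from compound 2 to compound 4 (beyond the scatter). Compound 4 is estimated at 22%, with a range of 8% to 38%.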

Compound 4, a percentage reported as inhibition, at one concentration (the size of the read-out at that concentration, not a potency): 17%
For compound 4 the middle estimate is 5 percentage points above the measured one, within the range that was stated.
By their numbers in this assay, from the lowest: compounds 4 and 3 (each within the scatter of the next); then compounds 2 and 1 (each within the scatter of the next).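

In this assay, for the compounds shown here, phenylsulfonyl in place of 3-chlorobenzyl on the aromatic nitrogen gives a number 26 percentage points lower from compound 2 to compound 4 (beyond the scatter), the first step that reads this change alone. The six-membered aromatic ring of carbon only stays in both groups, while hydrogen-bond acceptors enter and the chlorine leaves, so the step cannot be tied to the presence of that ring alone. No measurement at hand accounts for the step. Still open, on these data alone, is whether the step follows the sulfonyl link or the lost chlorine: an unsubstituted benzyl or a 3-chlorophenylsulfonyl on the same nitrogen would separate the two.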